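A few compounds are considered here, and "the series" means these few. Any claim that something is new, unique, unknown or untested is made for them only; others in the source may bear on it.

Measured so far in an assay on HEK293 cells for displacement of a labelled ligand from prostaglandin D2 receptor 2 (Homo sapiens); a lower number here means a stronger inhibitor, a higher number a weaker inhibitor:

Compound 1, `COc1ccccc1CSc1nc2ccccc2n1CC(=O)O`: 1100 nM
Compound 2, `O=C(O)Cn1c(SCc2ccccc2Br)nc2ccccc21`: 580 nM

Compound 1 has the higher of these two numbers, but only just: its nearest neighbour is compound 2, and a 1.9-fold lower number from compound 1 to compound 2 (0.28 log units; within the scatter). The two measured values therefore cannot be told apart with confidence.

The step followed here leads from compound 1 to compound 3, `COc1ccc(C)cc1CSc1nc2ccccc2n1CC(=O)O`, which has not yet been measured. The change is methyl in place of hydrogen on an aromatic carbon: a methyl enters on an aromatic carbon of a six-membered aromatic ring of carbon only, meta to a large group and para to a methoxy group, while a hydrogen leaves.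

Among the compounds with values here, only one measured step exists, and it concerns a different change, the exchange of methoxy for bromo on the same ring; that step stayed within the scatter. Within the data shown here, no measured step adds a methyl anywhere, so nothing points to a shift beyond the scatter in this assay, in either direction. Compound 3 is expected to give about 1000 nM, with a range of 400 nM to 2500 nM. The expected step is a 1.1-fold lower number from compound 1 to compound 3 (0.04 log units; within the scatter).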

Compound 3, half-maximal inhibitory concentration: 1200 nM
Compound 3: middle estimate off by 1.2-fold (0.08 log units), on the low side; the range from low to high includes it.
By their numbers in this assay, from the lowest: compounds 2, 1 and 3 (each within the scatter of the next, the first and the last beyond it).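

In this assay, placing a methyl on the aromatic carbon para to the methoxy group and meta to a large group gives a 1.1-fold higher number from compound 1 to compound 3 (0.04 log units; within the scatter). Within the data shown here, this is the only measured step at this position and the only one that adds a group instead of exchanging one, since compounds 1 and 2 differ solely by methoxy and bromo at another place on the same ring. It shows that, in the core of compound 1, this added methyl produces no difference that can be told from the usual variation between repeat measurements, and no measured evidence is available to explain that result.

A single small group cannot show whether this position would stay as undemanding with something else on it, such as an amine, a carboxylic acid or a longer chain. Going by these compounds, it also remains open whether a methyl here would behave the same way with bromo in place of methoxy, as in compound 2.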